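This account rests on a few compounds, and the source may have more. Where it says the series, first, only, none or still open, it means among the compounds named here.

Measured so far in a functional assay on A549 cells (Homo sapiens) for antiproliferative activity, tested at 1 uM; on this read-out higher numbers stand for more inhibition at the one concentration tested (going by the name of the read-out) and lower numbers for less inhibition:

compound 1 `COc1ccc(CO/N=C/c2c(C)nn(C)c2Oc2ccc(Cl)cc2)cc1` — 43.9%
compound 2 `Cc1ccc(CO/N=C/c2c(C)nn(C)c2Oc2ccc(Cl)cc2)cc1` — 50%
compound 3 `Cc1nn(C)c(Oc2ccc(Cl)cc2)c1/C=N/OCc1ccc(C(F)(F)F)cc1` — 50.9%

All three share one core and differ only in the group on an aromatic carbon of the six-membered aromatic ring of carbon only, para to a large group. Compound 3 gives the highest of the three numbers, but the step of a number 0.9 percentage points higher from compound 2 to compound 3 (within the scatter) and the step of a number 7 percentage points higher from compound 1 to compound 3 (within the scatter) are both within the scatter, as is a number 6.1 percentage points higher from compound 1 to compound 2 (within the scatter); the three values are therefore not separated by this assay.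

Compound 4 `Cc1nn(C)c(Oc2ccc(Cl)cc2)c1/C=N/OCc1ccc([N+](=O)[O-])cc1` is the next member of the same set. Its change from compound 3: nitro in place of trifluoromethyl on an aromatic carbon

Every measured step bears on this one, since each swaps the group at the same position: methyl for methoxy, trifluoromethyl for methoxy, trifluoromethyl for methyl. None of them moved the read-out beyond the scatter, and the swap of nitro for trifluoromethyl is of the same kind. No step beyond the scatter is expected in this assay for compound 4, in either direction; the expected step from compound 3 is a number 2.9 percentage points lower from compound 3 to compound 4 (within the scatter). The estimate for compound 4 is 48%, with a range from 36% to 60%.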

Compound 4, a percentage reported as inhibition, at one concentration (the size of the read-out at that concentration, not a potency): 39.6%
The estimate for compound 4 lay 8.4 percentage points above the measured number; measured number inside the range.
By their numbers in this assay, from the lowest: compounds 4, 1, 2 and 3 (each within the scatter of the next, the first and the last beyond it).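

In this assay the swap of nitro for trifluoromethyl gives a number 11.3 percentage points lower from compound 3 to compound 4 (beyond the scatter) and the swap of nitro for methyl gives a number 10.4 percentage points lower from compound 2 to compound 4 (beyond the scatter), so this position on the six-membered aromatic ring of carbon only, para to a large group, is not indifferent to what it carries, which the swaps among methoxy, methyl and trifluoromethyl could not show. The effect of nitro is only partly resolved, since the swap of nitro for methoxy gives a number 4.3 percentage points lower from compound 1 to compound 4 (within the scatter) and so leaves these two groups unseparated, while methoxy is in turn not separated from methyl or trifluoromethyl. Nothing measured on these compounds bears on why nitro parts from methyl and trifluoromethyl here.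

Open, going by these compounds, is whether the lower reading belongs to nitro alone or would also appear with other groups at this place, such as an amine, a nitrile or a carboxylic acid. Also open, on these data alone, is whether these modest steps would carry over to potency, as the read-out gives the size of inhibition at one concentration only.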